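A few compounds are considered here, and "the series" means these few. Any claim that something is new, unique, unknown or untested is made for them only; others in the source may bear on it.

In a functional assay on MGC-803 cells (Homo sapiens) for antiproliferative activity, read by MTT assay, with a stated time of 72 h (on this read-out higher numbers stand for weaker inhibition and lower numbers for stronger inhibition), compound 1 `C/C(=N\NC(=O)c1cccc(S(=O)(=O)N2CCOCC2)c1)c1ccc(F)cc1` gives > 100000 nM, which is a limit of the assay. For the measured compounds named here, compound 2 `C/C(=N\NC(=O)c1cccc(S(=O)(=O)N2CCOCC2)c1)c1ccc(O)cc1` gives 71400 nM, the only actual number so far. Compound 3 `C/C(=N\NC(=O)c1cccc(S(=O)(=O)N2CCOCC2)c1)c1cc(Br)ccc1O` carries 5-bromo-2-hydroxyphenyl in place of 4-hydroxyphenyl on a carbon with a double bond to nitrogen. Going by the values given here, the sole measured step, an at least 1.4-fold lower number from compound 1 to compound 2 (0.14 log units; that floor lies within the scatter), exchanges a different pair of groups and so gives only weak guidance, leaving the direction in this assay uncertain. A move towards stronger inhibition is expected, as an estimated 8.9-fold lower number from compound 2 to compound 3 (0.95 log units; beyond the scatter). For compound 3 the estimated value is 8000 nM, within a range from 500 nM to 70000 nM.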

Compound 3, half-maximal inhibitory concentration: 18000 nM
Beside the measured number, compound 3's estimate is 2.3-fold (0.35 log units) below it, and the stated range covers the measured number.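

At the carbon with a double bond to nitrogen, the aryl group now gives a change beyond the scatter in this assay, which the earlier step did not: a 4.0-fold lower number from compound 2 to compound 3 (0.60 log units; beyond the scatter). Exchanging 4-hydroxyphenyl for 5-bromo-2-hydroxyphenyl thus moves the number towards stronger inhibition. The step of an at least 5.5-fold lower number from compound 1 to compound 3 (0.74 log units; beyond the scatter) is only a floor, set by compound 1, whose value is a limit: the limit of > 100000 nM in this assay, at which 1 of the 3 values shown sits.

On these data alone, the bromine and the hydroxy of 5-bromo-2-hydroxyphenyl enter in one step, and their separate shares remain open. Also open, as far as these compounds go, is how an amine in place of that hydroxy would read.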